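The source may hold more compounds than are shown below. What is called first, only, known or untested is meant among the compounds shown, and "the series" means these compounds.

Measured so far:
compound 1 `CNC(=O)c1cc(C(=O)NCCCC2CNCCO2)cn(Cc2ccccc2)c1=O`, >= 194 ug/mL
compound 2 `CNC(=O)c1cc(C(=O)NC2CC2)cn(Cc2cccc3cn[nH]c23)c1=O`, >= 181 ug/mL

Of the compounds shown here, two have been read in a physicochemical assay for solubility; a lower number here means a less soluble compound, a higher number a more soluble compound. Compound 1 `CNC(=O)c1cc(C(=O)NCCCC2CNCCO2)cn(Cc2ccccc2)c1=O` comes back at >= 194 ug/mL, which is a limit of the assay and not a number. Compound 2 `CNC(=O)c1cc(C(=O)NC2CC2)cn(Cc2cccc3cn[nH]c23)c1=O` comes back at >= 181 ug/mL, likewise a limit. Among the measured compounds shown here, compound 1 therefore stands at the limit of >= 194 ug/mL in this assay, at which 1 of the 2 values shown sits, while the only other value shown sits at the limit of >= 181 ug/mL in this assay, at which 1 of the 2 values shown sits; both results are limits, so no order between the two compounds can be read from them.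

Compound 3 `CNC(=O)c1cc(C(N)=O)cn(Cc2ccccc2)c1=O` has not yet been measured in this assay. The change from compound 1 is hydrogen in place of 3-(morpholin-2-yl)propyl on an amide-type nitrogen. For the measured compounds named here, no step between measured compounds is available to calibrate this change, so direction and size rest on expectation alone. A drop beyond the usual scatter is expected, the step of an at least 2.7-fold lower number from compound 1 to compound 3 (0.44 log units; beyond the scatter). Compound 3 is estimated at 70 ug/mL, in a range from 20 ug/mL to 200 ug/mL.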

Compound 3, solubility: 71 ug/mL
Compound 3: the middle estimate sits 1.0-fold (0.01 log units) below what was measured, within the range that was stated.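

In this assay, among the compounds shown here, hydrogen in place of 3-(morpholin-2-yl)propyl on the amide-type nitrogen gives the first readable step: an at least 2.7-fold lower number from compound 1 to compound 3 (0.43 log units; beyond the scatter). For the compounds shown here, this shows that the read-out responds to the group at this position, and compound 3 supplies the first value that is a number and not a limit. The step is only a lower bound on the size of the change, as its upper end is unfixed for compound 1: the limit of >= 194 ug/mL in this assay, at which 1 of the 3 values shown sits.

The compounds shown do not tell whether the step belongs to the propyl chain or to the six-membered non-aromatic ring at its end. A plain propyl or a 3-aminopropyl on the same nitrogen would separate the two, and a true number for compound 1 would fix the full size of the step.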